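Pyrrolidin-1-yl in place of azetidin-1-yl

A few compounds are considered here, and "the series" means these few. Any claim that something is new, unique, unknown or untested is made for them only; others in the source may bear on it.

In an ADME assay on a cell-free system (plasma, Mus musculus) for protein binding, compound 1 `CNc1nccc(N2CC[C@H](NC(=O)Nc3ccc(CN(C)C)c(C(F)(F)F)c3)C2)n1` gives 87.8% and compound 2 `CNc1nccc(N2CC[C@H](NC(=O)Nc3ccc(CN4CCC4)c(C(F)(F)F)c3)C2)n1` gives 85.6%, so these two stand within the scatter of each other. Compound 3 `CNc1nccc(N2CC[C@H](NC(=O)Nc3ccc(CN4CCCC4)c(C(F)(F)F)c3)C2)n1` differs from compound 2 by pyrrolidin-1-yl in place of azetidin-1-yl on a saturated chain carbon bound to an aromatic carbon. Among the measured compounds shown here, the one measured step that bears on this is a 1.2-fold higher unbound fraction from compound 1 to compound 2 (0.07 log units; within the scatter), with azetidin-1-yl in place of dimethylamino at the same place. For the measured compounds named here, with only that small step as a guide, no change beyond the scatter is expected, and the estimated step is a 1.1-fold lower unbound fraction from compound 2 to compound 3 (0.04 log units; within the scatter). Compound 3 is expected to give 87%, within an estimated range of 80% to 92%.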

Compound 3, plasma protein binding: 87.2%
Estimate against measurement, compound 3: 1.0-fold (0.01 log units) (unbound fraction) above, and the stated range covers the measured number.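

In this assay the step from azetidin-1-yl to pyrrolidin-1-yl is small, with a 1.1-fold lower unbound fraction from compound 2 to compound 3 (0.05 log units; within the scatter) and, against dimethylamino, a 1.0-fold higher unbound fraction from compound 1 to compound 3 (0.02 log units; within the scatter) as well. All three amines on a saturated chain carbon bound to an aromatic carbon thus stand within the scatter of each other, so ring size and ring closure show no effect on the unbound fraction across these compounds. Nothing available here gives a reason for this. Still open, going by these compounds, is whether piperidin-1-yl, morpholin-4-yl or a carboxylic acid at this place would move the unbound fraction beyond the scatter.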